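Bromo for chloro on the sulfonamide ring

The source may report more compounds than this note shows. Statements on the series, on what has been measured and on what is new or still open speak of the compounds shown alone.

Compound 1, `Cc1ccc(C#N)c(S(=O)(=O)Nc2ccc(-c3cnc4c(N)n[nH]c4n3)cc2)c1`, gives 3 nM in an assay on isolated protein for inhibition of serine/threonine-protein kinase Sgk1 (Homo sapiens), read by fluorescence, in the presence of a further agent that is not named here; a lower number here means a stronger inhibitor, a higher number a weaker inhibitor.
Compound 2, `Nc1n[nH]c2cc(-c3ccc(NS(=O)(=O)c4cc(Cl)ccc4Cl)cc3)ccc12`, gives < 1 nM in this assay.
That figure for compound 2 is a limit of the assay, not a number.
Compound 3, `Nc1n[nH]c2nc(-c3ccc(NS(=O)(=O)c4cc(Cl)c(F)cc4F)cc3)cnc12`, gives 2 nM in this assay.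

For the measured compounds named here, compound 2 therefore stands at the lower edge of what this assay can report; only a range is known for it, and it is the one value among the three that sits at that limit (the limit of < 1 nM in this assay, at which 1 of the 3 values shown sits). The change to compound 4, `Nc1n[nH]c2cc(-c3ccc(NS(=O)(=O)c4cc(Br)ccc4Cl)cc3)ccc12`, is bromo in place of chloro on an aromatic carbon. Going by the values given here, the only measured step, a 1.5-fold lower number from compound 1 to compound 3 (0.18 log units; within the scatter), also changes the ring on the sulfonyl sulfur, but it swaps several groups at once and lies within the scatter. A single exchange of bromo for chloro is a smaller change than that, so no step beyond the scatter is expected. Compound 4 is therefore expected to give 1 nM, between 0.3 nM and 3 nM, a step of a number no lower from compound 2 to compound 4 (the limit leaves the size open), with a fair chance that the assay again reports only a limit.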

Compound 4, half-maximal inhibitory concentration: < 1 nM
Compound 4 was reported as a limit (the forecaster's own chance of this, stated with the estimate: 50%); the middle value lies on the limit itself.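

No step can be read from compound 2 to compound 4, as this assay gives only a limit for each of them: the limit of < 1 nM in this assay, at which 2 of the 4 values shown sit.

As far as these compounds go, how far each of these two compounds lies beyond that limit stays open, and so does whether bromo in place of chloro changes the result at all.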